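The source may report more compounds than this note shows. Statements on the series, on what has been measured and on what is new or still open speak of the compounds shown alone.

Among the measured compounds shown here, in a functional assay on PC-3 cells (Homo sapiens) for antiproliferative activity, read by MTT assay, with a stated time of 72 h (on this read-out lower numbers stand for stronger inhibition and higher numbers for weaker inhibition), compound 2 (`COc1ccc(/C=N/NC(=O)Nc2ccc(Oc3ccnc4[nH]ccc34)c(F)c2)cc1`) gives 6730 nM, the higher of the two numbers so far, while compound 1 (`O=C(N/N=C/c1ccc(O)cc1)Nc1ccc(Oc2ccnc3[nH]ccc23)c(F)c1`) gives 2780 nM. Compound 3 (`O=C(N/N=C/c1ccc(O)cc1O)Nc1ccc(Oc2ccnc3[nH]ccc23)c(F)c1`) carries 2,4-dihydroxyphenyl in place of 4-methoxyphenyl on a carbon with a double bond to nitrogen. For the measured compounds named here, the one measured step bearing on this is a 2.4-fold higher number from compound 1 to compound 2 (0.38 log units; beyond the scatter), modest and beyond the scatter, where a methyl replaces hydrogen on an oxygen on an aromatic ring. Going by the values given here, compound 3 lacks that methyl, but no measured step covers its second hydroxy group. A similar modest drop in this assay is therefore expected, namely a 2.6-fold lower number from compound 2 to compound 3 (0.41 log units; beyond the scatter). For compound 3 the estimated value is 2600 nM, with an expected range of 950 nM to 7000 nM.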

Compound 3, half-maximal inhibitory concentration: 13000 nM
Compound 3: middle estimate off by 5.0-fold (0.70 log units), on the low side; measured number outside the range, above it.
By their numbers in this assay, from the lowest: compound 1; then compounds 2 and 3 (each within the scatter of the next).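

In this assay, a second hydroxy group on the ring of compound 1 weakens inhibition, with a 4.7-fold higher number from compound 1 to compound 3 (0.67 log units; beyond the scatter), so this aromatic ring does not accept the extra hydroxy group without loss. Exchanging 4-methoxyphenyl for 2,4-dihydroxyphenyl gives a 1.9-fold higher number from compound 2 to compound 3 (0.29 log units; within the scatter), so the gain expected from losing the methyl does not appear once the second hydroxy group is present. No outside evidence bears on this result. Going by these compounds, whether an amine or a chlorine atom in that hydroxy group's place would be tolerated remains open.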